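Phenyl replaces ethoxycarbonyl on the double-bonded chain carbon

The source may report more compounds than this note shows. Statements on the series, on what has been measured and on what is new or still open speak of the compounds shown alone.

Compound 2 `CCOC(=O)/C=C1\C(=O)N(Cc2ccc(OC)cc2)c2ccc(-c3ccc(OC)cc3)cc21` gives 3390 nM in a functional assay on HepG2 cells (Homo sapiens) for antiproliferative activity, read by MTT assay, with a stated time of 48 h (on this read-out higher numbers stand for weaker inhibition and lower numbers for stronger inhibition), the highest of the two numbers in hand. Compound 1 `COc1ccc(-c2ccc3c(c2)C(=O)C(=O)N3Cc2ccc(OC)c(OC)c2)cc1` gives 1350 nM in this assay, a lower number, a gap beyond the usual scatter. Compound 3 `COc1ccc(CN2C(=O)/C(=C\c3ccccc3)c3cc(-c4ccc(OC)cc4)ccc32)cc1` differs from compound 2 by phenyl in place of ethoxycarbonyl on a double-bonded chain carbon bound to a double-bonded ring carbon. Among the measured compounds shown here, no measured pair shows this change, so its size cannot be read from the numbers available; a modest step toward a lower number, near the edge of the scatter, is expected. Compound 3 is estimated at 2000 nM in this assay, with a range from 600 nM to 7000 nM. This expected step from compound 2 to compound 3 is a 1.7-fold lower number from compound 2 to compound 3 (0.23 log units; within the scatter).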

Compound 3, half-maximal inhibitory concentration: > 10000 nM
Compound 3: only a limit was reported (the forecaster's own chance of this, stated with the estimate: 5%); middle value at least 5.0-fold (0.69 log units) from the limit.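

In this assay compound 3 gives > 10000 nM, which is a limit of the assay and not a number. Phenyl in place of ethoxycarbonyl on a double-bonded chain carbon bound to a double-bonded ring carbon gives an at least 2.9-fold higher number from compound 2 to compound 3 (0.46 log units; beyond the scatter), so this position is not indifferent to the group it carries. On this single pair, ethoxycarbonyl keeps a measurable value and phenyl does not.

Only a lower bound on the size of this step can be read: the limit of > 10000 nM in this assay, at which 1 of the 3 values shown sits.
On these data alone, whether an amine or a carboxylic acid on this carbon would give a lower number in this assay remains open.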